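Three Aryl Variants Measured, a Fourth Awaiting Its Number

The source may report more compounds than this note shows. Statements on the series, on what has been measured and on what is new or still open speak of the compounds shown alone.

Measured so far in an assay on cells for displacement of a labelled ligand from prostaglandin E2 receptor EP4 subtype (Homo sapiens), read by scintillation counting; on this read-out higher numbers stand for weaker inhibition and lower numbers for stronger inhibition:
compound 1, `COc1ccc(-c2ccc(OCc3cc(C(=O)NS(=O)(=O)c4ccccc4)oc3C)cc2)c(C)c1`: 21 nM
compound 2, `Cc1oc(C(=O)NS(=O)(=O)c2ccccc2)cc1COc1ccc(-c2ccccc2)cc1`: 25 nM
compound 3, `CC(=O)c1ccc(-c2ccc(OCc3cc(C(=O)NS(=O)(=O)c4ccccc4)oc3C)cc2)cc1`: 20 nM

All three share the same core and differ only in the outer aromatic ring. On the numbers shown, compound 3 has the lowest value, yet every gap to its neighbours is small: a 1.1-fold lower number from compound 1 to compound 3 (0.02 log units; within the scatter) and a 1.3-fold lower number from compound 2 to compound 3 (0.10 log units; within the scatter) both fall inside the usual scatter, as does a 1.2-fold higher number from compound 1 to compound 2 (0.08 log units; within the scatter). So none of the three can be called more or less potent than another; the three aryl groups tried so far read as interchangeable within this assay.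

Compound 4, `Cc1oc(C(=O)NS(=O)(=O)c2ccccc2)cc1COc1ccc(-c2ccc(OC(F)F)cc2)cc1`, continues from compound 3 with a single change: difluoromethoxy in place of acetyl on an aromatic carbon. For the measured compounds named here, the steps that bear on this are the three already described, each of which swapped or added a group on that same outer ring without moving the number beyond the scatter. A fourth such swap, exchanging one small oxygen-bearing group for another at the same place, gives no ground to expect anything different. Compound 4 is therefore expected to sit close to compound 3, with a 1.1-fold higher number from compound 3 to compound 4 (0.02 log units; within the scatter), and an estimated value of 21 nM, likely between 8 nM and 55 nM.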

Compound 4, inhibition constant: 1.3 nM
Compound 4: the middle estimate sits 16-fold (1.21 log units) above what was measured; measured number outside the range, below it.
By their numbers in this assay, from the lowest: compound 4; then compounds 3, 1 and 2 (each within the scatter of the next).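

In this assay, the outer ring had seemed indifferent to what it carried, but this result shows that the position para to a large group can matter a great deal: difluoromethoxy in place of acetyl gives a 15-fold lower number from compound 3 to compound 4 (1.19 log units; beyond the scatter), the same group in place of hydrogen gives a 19-fold lower number from compound 2 to compound 4 (1.28 log units; beyond the scatter), and 4-(difluoromethoxy)phenyl in place of 4-methoxy-2-methylphenyl gives a 16-fold lower number from compound 1 to compound 4 (1.21 log units; beyond the scatter). Simply having a group at this place is not enough, as acetyl in place of hydrogen gives only a 1.3-fold lower number from compound 2 to compound 3 (0.10 log units; within the scatter), which lies within the scatter, so the large steps here are tied to difluoromethoxy itself. No measurement among these data explains why this group stands apart from the others.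

The compounds shown leave open whether the two fluorines are needed, a question that a lone methoxy group or a trifluoromethoxy group at the same place on the otherwise unchanged ring would help to settle. They also leave open whether difluoromethoxy would give a similar step at another place on this ring, or on a compound with a different group in place of the benzene ring on the sulfonyl.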